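The compounds below may be only part of what the source reports. "The series", "measured", "known", "first", "only" and "open" are said of these compounds alone.

Measured compounds:
- compound 1 `Cn1cncc1CN1CC(N(CC2CCN(S(C)(=O)=O)CC2)S(=O)(=O)c2ccccn2)Cc2cc(C#N)ccc21`: 0.1 10^-6 cm/s
- compound 2 `Cc1noc(C)c1CN(C1Cc2cc(C#N)ccc2N(Cc2cncn2C)C1)S(=O)(=O)c1ccccn1`: 8 10^-6 cm/s
- compound 3 `Cn1cncc1CN1CC(N(CCn2cccc2)S(=O)(=O)c2ccccn2)Cc2cc(C#N)ccc21`: 12.4 10^-6 cm/s

In an ADME assay on Caco-2 cells (Homo sapiens) for permeability, in the apical to basolateral direction (a higher number here means that the compound crosses the layer faster, a lower number that the compound crosses the layer more slowly), compound 1 stands lowest of the three numbers; its nearest neighbour is compound 2, an 80-fold higher number from compound 1 to compound 2 (1.90 log units; beyond the scatter), and the widest gap is to compound 3, a 120-fold higher number from compound 1 to compound 3 (2.09 log units; beyond the scatter). Between compound 2 and compound 3 the difference, a 1.6-fold higher number from compound 2 to compound 3 (0.19 log units; within the scatter), stays within the scatter.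

Compound 4 `Cn1cncc1CN1CC(N(CC2CCN(S(=O)(=O)c3ccccc3)CC2)S(=O)(=O)c2ccccn2)Cc2cc(C#N)ccc21` is the unmeasured member. It differs from compound 1 as follows: phenyl in place of methyl on a sulfonyl sulfur. The two large measured steps, an 80-fold higher number from compound 1 to compound 2 (1.90 log units; beyond the scatter) and a 120-fold higher number from compound 1 to compound 3 (2.09 log units; beyond the scatter), both remove the whole 1-(methylsulfonyl)piperidin-4-yl group and put a different ring in its place. In compound 4 that group stays; only the methyl on its sulfonyl sulfur becomes phenyl. Among the measured compounds shown here, no measured pair tests that change, so the two large steps set only a loose upper bound for what a change at this group can do, and nothing requires a step of their size here.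

The expectation is therefore for compound 4 a step of a 3.0-fold higher number from compound 1 to compound 4 (0.48 log units; beyond the scatter) in this assay, upward but small, near the edge of the scatter. The estimate for compound 4 in this assay is 0.3 10^-6 cm/s, with a range from 0.08 10^-6 cm/s to 1.2 10^-6 cm/s.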

Compound 4, apparent permeability: 0.1 10^-6 cm/s
Compound 4: the middle estimate sits 3.0-fold (0.48 log units) above what was measured; low and high end bracket the measured number.
By their numbers in this assay, from the lowest: compounds 1 and 4 (each within the scatter of the next); then compounds 2 and 3 (each within the scatter of the next).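

In this assay the change from methylsulfonyl to phenylsulfonyl reads as no change at the digits printed from compound 1 to compound 4 (within the scatter) and so shows that this sulfonyl sulfur accepts a six-membered aromatic ring of carbon only in place of methyl with no readable shift in the number. The large steps of an 80-fold higher number from compound 1 to compound 2 (1.90 log units; beyond the scatter) and a 120-fold higher number from compound 1 to compound 3 (2.09 log units; beyond the scatter) both replaced the whole 1-(methylsulfonyl)piperidin-4-yl group, whereas this result shows that keeping the sulfonyl on its ring nitrogen and enlarging only the group on the sulfur leaves the read-out where it was. No supporting measurement is available to account for this outcome.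

It remains open which part of the 1-(methylsulfonyl)piperidin-4-yl group accounts for the large steps, the sulfonyl or the saturated ring that carries it. The compounds shown also leave open what an acetyl group or a plain hydrogen on that ring nitrogen would give in place of the sulfonyl, and what an amine or a carboxylic acid on the phenyl ring would give.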